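Solubility after swapping the indoline for a phthalimidomethyl group

This account rests on a few compounds, and the source may have more. Where it says the series, first, only, none or still open, it means among the compounds named here.

Measured so far:
compound 1 `COc1ccc2[nH]c(C(=O)N3CC(=O)N(Cc4ccccc4)[C@@H](COc4ccccc4)C3)cc2c1` — 12200 nM
compound 2 `COc1ccc2[nH]c(C(=O)N3CC(=O)N(Cc4ccccc4)[C@@H](N4CCc5ccccc54)C3)cc2c1` — 7000 nM

Going by the values given here, in a physicochemical assay for solubility, read by spectrophotometry, in phosphate buffer, with a stated time of 2 h, at pH 7.4 (a higher number here means a more soluble compound, a lower number a less soluble compound), compound 2 gives the lower of the two numbers, and its only neighbour is compound 1, but the difference a 1.7-fold lower number from compound 1 to compound 2 (0.24 log units; within the scatter) lies within the scatter. Compound 3 `COc1ccc2[nH]c(C(=O)N3CC(=O)N(Cc4ccccc4)[C@@H](CN4C(=O)c5ccccc5C4=O)C3)cc2c1` differs from compound 2 by a group of 12 heavy atoms (9 carbon, 1 nitrogen, 2 oxygen; one five-membered non-aromatic ring with 1 hetero atom, one six-membered aromatic ring of carbon only) in place of a group of 9 heavy atoms (8 carbon, 1 nitrogen; one five-membered non-aromatic ring with 1 hetero atom, one six-membered aromatic ring of carbon only), on a saturated ring carbon. Among the compounds with values here, the one step measured at this position, a 1.7-fold lower number from compound 1 to compound 2 (0.24 log units; within the scatter), was within the scatter, so no step beyond the scatter is expected in this assay; the estimated step is a 1.2-fold lower number from compound 2 to compound 3 (0.07 log units; within the scatter). Compound 3 is therefore expected at about 6000 nM, between 2000 nM and 18000 nM.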

Compound 3, solubility: > 100000 nM
Compound 3 gave a limit, no number (the forecaster's own chance of this, stated with the estimate: 5%); at least 16-fold (1.22 log units) between middle value and limit.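

The position is not flat for solubility: swapping this group on the saturated ring carbon can give a step well beyond the scatter, an at least 14-fold higher number from compound 2 to compound 3 (1.15 log units; beyond the scatter). The same holds against the phenoxymethyl group, an at least 8.1-fold higher number from compound 1 to compound 3 (0.91 log units; beyond the scatter). The value of compound 3 is a limit and not a number: the limit of > 100000 nM in this assay, at which 1 of the 3 values shown sits.

Which part of the entering group goes with this step, its two carbonyls or its ring as a whole, stays open. Also open, as far as these compounds go, is whether a smaller acetamidomethyl group or a plain aminomethyl group at this position would give a similar step.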